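The source may hold more compounds than are shown below. What is called first, only, known or untested is meant among the compounds shown, and "the series" means these compounds.

Compound 1 `Nc1scc(CN2CCN(c3ccc(Cl)cc3Cl)CC2)c1C(=O)c1ccc(Cl)cc1`: -54%
Compound 2 `Nc1scc(CN2CCN(C3CCCCCC3)CC2)c1C(=O)c1ccc(Cl)cc1`: 3.7%

For the measured compounds named here, in a functional assay on CHO cells with adenosine receptor A1 (Homo sapiens) as the target, read by cAMP accumulation and immunoassay, with a stated time of 6 min, tested at 1 uM (on this read-out higher numbers stand for a weaker effect at the one concentration tested and lower numbers for a stronger effect), compound 1 gives -54% and compound 2 gives 3.7%, so compound 2 stands highest of the two numbers, the weaker effect, with compound 1 the only other compound and lower. Compound 3 `Nc1scc(CN2CCN(c3cccc(F)c3)CC2)c1C(=O)c1ccc(Cl)cc1` differs from compound 2 by 3-fluorophenyl in place of cycloheptyl on an amine nitrogen in a ring. Going by the values given here, only one measured step bears on this change: a number 57.7 percentage points higher from compound 1 to compound 2 (beyond the scatter), which replaced one six-membered aromatic ring on that ring nitrogen with a seven-membered non-aromatic ring. Compound 3 puts a six-membered aromatic ring back in the same place, so a downward step, roughly undoing that one, is expected, though the 3-fluorophenyl is not the same ring as the 2,4-dichlorophenyl of compound 1 and the size is uncertain. The step of a number 33.7 percentage points lower from compound 2 to compound 3 (beyond the scatter) is the expected one. Compound 3 is therefore estimated at -30%, within -65% to 5%.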

Compound 3, a percentage reported as activity, at one concentration (the size of the read-out at that concentration, not a potency): -86%
Estimate against measurement, compound 3: 56 percentage points above; the whole stated range lies above it.
By their numbers in this assay, from the lowest: compound 3; then compound 1; then compound 2.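

In this assay, putting 3-fluorophenyl in place of cycloheptyl on the amine nitrogen gives a number 89.7 percentage points lower from compound 2 to compound 3 (beyond the scatter), so both compounds with a six-membered aromatic ring at this position now read lower than the cycloheptyl compound, and none of the three goes against this. The aromatic rings are not interchangeable either: 3-fluorophenyl in place of 2,4-dichlorophenyl gives a number 32 percentage points lower from compound 1 to compound 3 (beyond the scatter), which shows that the groups on the aromatic ring also matter here. Nothing measured here gives a reason for these differences.

The compounds shown leave open whether the fluorine, its place on the ring or the absence of the two chlorines accounts for that last step. Also open, on these data alone, is how a plain phenyl or a benzyl on the same nitrogen would read.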